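Aryl amide variation on the shared core: compound 4

The source may hold more compounds than are shown below. What is called first, only, known or untested is meant among the compounds shown, and "the series" means these compounds.

Compound 1 `CN1CCC(c2c[nH]c3ccc(NC(=O)C4CC4)nc23)CC1` carries a cyclopropyl on the amide carbonyl and gives 9.8 nM in an assay for binding affinity to 5-hydroxytryptamine receptor 1F (Homo sapiens), read by radioligand binding; on this read-out higher numbers stand for weaker inhibition and lower numbers for stronger inhibition. Compound 2 `CN1CCC(c2c[nH]c3ccc(NC(=O)c4cccc(F)c4)nc23)CC1` gives 11 nM; compound 3 `Cc1cccc(C(=O)Nc2ccc3[nH]cc(C4CCN(C)CC4)c3n2)c1` gives 5.8 nM. Compound 3 has the lowest of the three numbers, but its steps to the others are within the scatter: a 1.7-fold lower number from compound 1 to compound 3 (0.23 log units; within the scatter) and a 1.9-fold lower number from compound 2 to compound 3 (0.28 log units; within the scatter). The remaining step, a 1.1-fold higher number from compound 1 to compound 2 (0.05 log units; within the scatter), is also within the scatter, so the three amide groups are not separated on this read-out.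

Compound 4 `CN1CCC(c2c[nH]c3ccc(NC(=O)c4ccc(C#N)cc4)nc23)CC1` is not yet measured. Against compound 3 the change is 4-cyanophenyl in place of 3-methylphenyl on a carbonyl carbon. For the measured compounds named here, no measured step covers a cyanophenyl or a substituent in this position; the steps that bear on it show only that exchanging cyclopropyl, 3-fluorophenyl and 3-methylphenyl on the carbonyl carbon moves the number within the scatter. The step from compound 3 to compound 4 is therefore expected to be a 1.4-fold higher number from compound 3 to compound 4 (0.14 log units; within the scatter), with no direction beyond the scatter. For compound 4 the estimate in this assay is 8 nM, range 3 nM to 25 nM.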

Compound 4, inhibition constant: 7.2 nM
Compound 4: middle estimate off by 1.1-fold (0.05 log units), on the high side, and the stated range covers the measured number.
By their numbers in this assay, from the lowest: compounds 3, 4, 1 and 2 (each within the scatter of the next).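

Of the four groups on the carbonyl carbon, only 4-cyanophenyl carries a triple bond and a hydrogen-bond acceptor, yet in this assay it stays within the scatter of all three others: (a 1.2-fold higher number from compound 3 to compound 4 (0.09 log units; within the scatter)), (a 1.5-fold lower number from compound 2 to compound 4 (0.18 log units; within the scatter)) and (a 1.4-fold lower number from compound 1 to compound 4 (0.13 log units; within the scatter)). The flat picture among cyclopropyl, 3-fluorophenyl and 3-methylphenyl therefore also holds for this nitrile-bearing group, so all four compounds remain unseparated on this read-out. Nothing available offers an explanation for this flat result.

As far as these compounds go, whether an amine or a carboxylic acid on the aromatic ring, or a longer alkyl chain on the carbonyl carbon, would move the number beyond the scatter remains open. Also open, from the compounds shown here alone, is whether any of these amide groups would separate on a core other than the shared one.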